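The source may report more compounds than this note shows. Statements on the series, on what has been measured and on what is new or still open speak of the compounds shown alone.

In a functional assay on MKN-45 cells (Homo sapiens) for antiproliferative activity, read by MTT assay, with a stated time of 72 h (a lower number here means a stronger inhibitor, a higher number a weaker inhibitor), compound 1 `COc1cc(CCc2ccncc2)cc(OC)c1O` gives 3810 nM, while compound 2 `COc1cc(CCc2ccccc2)cc(OC)c1O` gives 1040 nM. Compound 2 therefore holds the lower of the two numbers and is the stronger inhibitor of this pair. Going by the values given here, only one measured step is available: a 3.7-fold lower number from compound 1 to compound 2 (0.56 log units; beyond the scatter), which comes with phenyl in place of pyridin-4-yl on the chain. Compound 3 `COc1cc(CCc2ccccc2Cl)cc(OC)c1O` keeps everything in compound 2 except for one change on the phenyl ring: chloro in place of hydrogen on an aromatic carbon. Chloro takes the place of hydrogen on an aromatic carbon, ortho to a large group. Among the compounds with values here, no measured compound carries a chloro, so the single step is only a loose guide to scale, as it involves swapping a whole ring rather than adding one atom. In this assay, a step no larger than that one is expected, most likely within the scatter and leaning slightly toward a lower number. The expected change is a 1.3-fold lower number from compound 2 to compound 3 (0.11 log units; within the scatter). For compound 3, the estimated value is 800 nM, with an expected range from 270 nM to 2400 nM.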

Compound 3, half-maximal inhibitory concentration: 24500 nM
Estimate against measurement, compound 3: 31-fold (1.49 log units) below, and the stated range ends below it.
By their numbers in this assay, from the lowest: compound 2; then compound 1; then compound 3.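

In this assay, one added chloro on an aromatic carbon of the phenyl ring, ortho to a large group, gives a 24-fold higher number from compound 2 to compound 3 (1.37 log units; beyond the scatter) and so turns compound 2 into a much weaker inhibitor with a change of only 1 heavy atom. Going by these compounds alone, the only earlier step, a 3.7-fold lower number from compound 1 to compound 2 (0.56 log units; beyond the scatter), exchanged a whole ring yet is printed as modest, whereas this one is large, so the size of a structural change is a poor guide to the size of its effect in this pair of steps. Nothing available bears on why this single chloro costs so much activity.

Open, on these data alone, is whether the loss belongs to chloro itself or to this place on the ring, which a fluoro, a methyl or a methoxy on the same carbon, or a chloro on another carbon of the phenyl ring, could help to separate. Also open, as far as these compounds go, is whether a chloro at the matching place on the pyridin-4-yl ring of compound 1 would bring a step of similar size.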